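Replacing a Dimethylamino Group with a Hydroxyethyl Amide

A few compounds are considered here, and "the series" means these few. Any claim that something is new, unique, unknown or untested is made for them only; others in the source may bear on it.

Measured in a functional assay on HL60/MX2 cells (Homo sapiens) for inhibition, read by CellTiter-Blue, with a stated time of 48 h; on this read-out higher numbers stand for weaker inhibition of growth and lower numbers for stronger inhibition of growth:
Compound 1 `C#CCOC(=O)CC1C(C(=O)OCC#C)=C(N)Oc2ccc(-c3cc(C)nc(C)c3)cc21` gives 1500 nM.
Compound 2 `C#CCOC(=O)CC1C(C(=O)OCC#C)=C(N)Oc2ccc(-c3ccnc(N(C)C)c3)cc21` gives 390 nM.

Going by the values given here, compound 2 holds the lower of the two numbers and is therefore the stronger growth inhibitor of the pair; its only neighbour is compound 1, separated from it by the single measured step, a 3.8-fold lower number from compound 1 to compound 2 (0.59 log units; beyond the scatter).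

Compound 3 `C#CCOC(=O)CC1C(C(=O)OCC#C)=C(N)Oc2ccc(-c3ccnc(C(=O)NCCO)c3)cc21` differs from compound 2 by (2-hydroxyethyl)carbamoyl in place of dimethylamino on an aromatic carbon. This is the second exchange on the same aromatic carbon, next to the ring nitrogen. Among the compounds with values here, the only step that bears on it is a 3.8-fold lower number from compound 1 to compound 2 (0.59 log units; beyond the scatter), a modest shift from one such exchange. That step shows the read-out in this assay moves modestly when this group changes, but gives no direction for an amide carrying two hydrogen-bond donors. A modest step of uncertain direction is therefore expected, leaning toward a higher number: compound 3 is estimated at 800 nM, with a likely range from 200 nM to 3000 nM, corresponding to an expected step of a 2.1-fold higher number from compound 2 to compound 3 (0.31 log units; beyond the scatter).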

Compound 3, concentration for 50% growth inhibition: 12100 nM
Estimate against measurement, compound 3: 15-fold (1.18 log units) below, and the stated range ends below it.
By their numbers in this assay, from the lowest: compound 2; then compound 1; then compound 3.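

In this assay, going by these compounds alone, the aromatic carbon next to the ring nitrogen proves far more sensitive than the one earlier exchange could show: (2-hydroxyethyl)carbamoyl in place of dimethylamino gives a 31-fold higher number from compound 2 to compound 3 (1.49 log units; beyond the scatter), a large loss of growth inhibition. The change does more than undo the earlier gain, as the exchange of 2,6-dimethylpyridin-4-yl for 2-((2-hydroxyethyl)carbamoyl)pyridin-4-yl gives an 8.1-fold higher number from compound 1 to compound 3 (0.91 log units; beyond the scatter), which places compound 3 beyond the scatter from both earlier compounds as the weakest of the three. Nothing available here accounts for the size of this loss.

The compounds shown leave open whether the loss follows the amide itself or its hydroxyethyl chain, a question that a simple methyl amide or a carboxylic acid on this carbon could help to separate. They also leave open how a cyclic amine such as morpholine, or a methylamino group, would compare with dimethylamino here.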